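A few compounds are considered here, and "the series" means these few. Any claim that something is new, unique, unknown or untested is made for them only; others in the source may bear on it.

Among the compounds with values here, in a functional assay on HCT-116 cells (Homo sapiens) for antiproliferative activity, read by MTT assay, with a stated time of 72 h (on this read-out lower numbers stand for stronger inhibition and higher numbers for weaker inhibition), compound 1 `O=S1(=O)C=Cc2cccc(Nc3cccc(C(F)(F)F)c3)c21` gives 330 nM, the lowest of the three numbers measured so far. Compound 3 `O=S1(=O)C=Cc2cccc(Nc3cccc(F)c3)c21` gives 1220 nM, and compound 2 `O=S1(=O)C=Cc2cccc(Nc3c(F)c(F)c(F)c(F)c3F)c21` gives 3370 nM. Compound 4 `O=S1(=O)C=Cc2cccc(Nc3cc(C(F)(F)F)cc(C(F)(F)F)c3)c21` has not yet been measured. It differs from compound 1 in one place: trifluoromethyl in place of hydrogen on an aromatic carbon. This puts trifluoromethyl in place of hydrogen on an aromatic carbon, meta to a trifluoromethyl group.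

Within the data shown here, only one measured step bears on this change: a 3.7-fold higher number from compound 1 to compound 3 (0.57 log units; beyond the scatter), with fluoro in place of trifluoromethyl on an aromatic carbon. That step is modest but beyond the scatter. Among the measured compounds shown here, it swaps one group for another, however, and no measured compound carries a second trifluoromethyl, so the direction of the new step remains open. No step beyond the scatter is therefore expected in this assay. For compound 4 the expected value is 300 nM, with an estimated range from 100 nM to 900 nM. This estimate means an expected 1.1-fold lower number from compound 1 to compound 4 (0.04 log units; within the scatter).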

Compound 4, half-maximal inhibitory concentration: 3600 nM
Compound 4: middle estimate off by 12-fold (1.08 log units), on the low side; measured number above the stated range.
By their numbers in this assay, from the lowest: compound 1; then compound 3; then compounds 2 and 4 (each within the scatter of the next).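

In this assay the added trifluoromethyl is far from a neutral change: the step is an 11-fold higher number from compound 1 to compound 4 (1.04 log units; beyond the scatter) and counts as large, in the direction of weaker inhibition. Within the data shown here, this position, which holds only hydrogen in compound 1, therefore does not simply accept a second trifluoromethyl, even though a first one is present in the compound with the lowest number so far. No measurement shown here explains why the number rises.

Going by these compounds, it remains open whether this loss belongs to trifluoromethyl alone or would come with any group at this position, and a methyl, a chlorine or a methoxy there would separate these cases. On these data alone, it is also open whether the step depends on the first trifluoromethyl, which a compound carrying only the new group would show.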